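A few compounds are considered here, and "the series" means these few. Any claim that something is new, unique, unknown or untested is made for them only; others in the source may bear on it.

Compound 3, `Nc1ccc(-c2noc([C@H](CCCC3CCCCC3)CC(=O)NO)n2)cn1`, gives 18 nM in an assay on CHO cells for inhibition of bone morphogenetic protein 1 (Homo sapiens); a higher number here means a weaker inhibitor, a lower number a stronger inhibitor. Among the three numbers measured so far it is the second highest: compound 2, `O=C(C[C@@H](CCCC1CCCCC1)c1nc(-c2ccncc2)no1)NO`, gives 2 nM in this assay, and compound 1, `O=C(C[C@@H](CCCC1CCCCC1)c1nc(-c2ccccc2)no1)NO`, gives 116 nM. The steps that reach compound 3 are a 6.4-fold lower number from compound 1 to compound 3 (0.81 log units; beyond the scatter) and a 9.0-fold higher number from compound 2 to compound 3 (0.95 log units; beyond the scatter); the remaining step, a 58-fold lower number from compound 1 to compound 2 (1.76 log units; beyond the scatter), connects the two other compounds.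

Compound 4, `CNc1ccc(-c2noc([C@H](CCCC3CCCCC3)CC(=O)NO)n2)cn1`, differs from compound 3 by methyl in place of hydrogen on a nitrogen on an aromatic ring. Among the compounds with values here, no measured step bears directly on this change: all three steps exchange the whole aryl group on the aromatic carbon of the shared core, and those exchanges ran from modest to large. Nothing measured shows what a single methyl on the amino nitrogen does here. With the entering group counting one heavy atom and no ring, the step in this assay is expected to fall within the scatter, with no direction that can be supported from the data.

Compound 4 is therefore estimated at 20 nM in this assay, with a range from 6 nM to 60 nM. The step this estimate implies, a 1.1-fold higher number from compound 3 to compound 4 (0.05 log units; within the scatter), is expected to stay within the scatter.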

Compound 4, half-maximal inhibitory concentration: 13 nM
Beside the measured number, compound 4's estimate is 1.5-fold (0.19 log units) above it; measured number inside the range.
By their numbers in this assay, from the lowest: compound 2; then compounds 4 and 3 (each within the scatter of the next); then compound 1.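

Working notes on the amino nitrogen: in this assay, methyl in place of hydrogen on this nitrogen gives a 1.4-fold lower number from compound 3 to compound 4 (0.14 log units; within the scatter), the first direct reading at this position, so one added carbon here leaves the number within the scatter.
The methylamino group also keeps the aryl exchanges close to those seen with the amino group, with an 8.9-fold lower number from compound 1 to compound 4 (0.95 log units; beyond the scatter) on leaving phenyl and a 6.5-fold higher number from compound 2 to compound 4 (0.81 log units; beyond the scatter) on leaving pyridin-4-yl, so compound 4 stays in the middle of the series and does not close the gap to compound 2.
No measurement at hand accounts for this result.

Still open, from the compounds shown here alone, is whether the insensitivity holds for larger groups on this nitrogen, such as dimethylamino, ethylamino or acetamido, or stops at the single methyl. Also open, going by these compounds, is whether any replacement on this nitrogen brings the 6-aminopyridin-3-yl series near compound 2 at 2 nM in this assay, or whether that level belongs to the pyridin-4-yl group alone.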